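Extending a Hydroxyl Chain on Two Related Cores

A few compounds are considered here, and "the series" means these few. Any claim that something is new, unique, unknown or untested is made for them only; others in the source may bear on it.

Compound 1 `COc1ccc2cc(CO)oc(=O)c2c1` and compound 2 `COc1ccc2cc(CCCO)oc(=O)c2c1` share one core and were both tested in a functional assay on HT-29 cells (Homo sapiens) for antiproliferative activity, read by sulforhodamine B assay, with a stated time of 48 h; a higher number here means a weaker inhibitor of growth, a lower number a stronger inhibitor of growth. In this assay compound 1 gives 80.3 ug/mL, while compound 2 gives 29.1 ug/mL. The change between them, (2-hydroxyethyl in place of hydroxy on a saturated chain carbon bound to an aromatic carbon), produced a 2.8-fold lower number from compound 1 to compound 2 (0.44 log units; beyond the scatter). Compound 3 `COc1ccc2c(c1)C(=O)OC(CO)C2` rests on a different core; the difference between the two cores is not broken down here. In this assay compound 3 reaches only a limit of the assay, >= 250 ug/mL, and (the limit of >= 250 ug/mL in this assay, at which 1 of the 3 values shown sits). Compound 4 `COc1ccc2c(c1)C(=O)OC(CCCO)C2` carries the same kind of change, (2-hydroxyethyl in place of hydroxy on a saturated chain carbon bound to a saturated ring carbon), but at a different place: on a saturated chain carbon bound to a saturated ring carbon rather than to an aromatic carbon. This expectation rests on a 2.8-fold lower number from compound 1 to compound 2 (0.44 log units; beyond the scatter). For compound 4 a step of about an at least 1.6-fold lower number from compound 3 to compound 4 (0.22 log units; that floor lies within the scatter) is expected. Compound 4 is thus estimated at 150 ug/mL, between 60 ug/mL and 400 ug/mL.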

Compound 4, concentration for 50% growth inhibition: 132 ug/mL
Beside the measured number, compound 4's estimate is 1.1-fold (0.06 log units) above it; the measured number falls inside the stated range.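

Going from hydroxymethyl to 3-hydroxypropyl on the second core gave an at least 1.8-fold lower number from compound 3 to compound 4 (0.27 log units; that floor lies within the scatter) in this assay, which points the same way as the step on the first core. This does not show that the change carries over with the same size, since only a floor is known for the second step: the same change on two cores in this assay, a 2.8-fold lower number (0.44 log units; beyond the scatter) from compound 1 to compound 2 and an at least 1.8-fold lower number (0.27 log units; that floor lies within the scatter) from compound 3 to compound 4; the limit leaves it open whether they differ The value for compound 3 is a limit and not a number, and the true size of the step stays unknown with it: the limit of >= 250 ug/mL in this assay, at which 1 of the 4 values shown sits.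

The compounds shown leave open how a longer chain ending in hydroxy would fare on either core. They also leave open whether an amine or a carboxylic acid at the end of the 3-hydroxypropyl chain, in place of the hydroxy, would follow the same course.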